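The compounds below may be only part of what the source reports. "The series", "measured", "known", "first", "only" and "open" are said of these compounds alone.

Working notes on the series. The shared core is that of compound 1, `CC(C)=CCC[C@]1(C)/C=C/[C@@H](OC(=O)C=C(C)C)[C@](C)(O)/C=C/C(=O)/C(C(=O)O)=C\C1`, which carries a carboxy group on the conjugated ketone side. In a functional assay on SW480 cells (Homo sapiens) for antiproliferative activity, read by MTT assay, with a stated time of 48 h (on this read-out lower numbers stand for stronger inhibition and higher numbers for weaker inhibition), compound 1 gives > 10000 nM; this is a limit of the assay, not a number, so compound 1 stands at the limit of > 10000 nM in this assay, at which 1 of the 3 values shown sits, and nothing more exact is known of it. Compound 2, `CC(C)=CCC[C@]1(C)/C=C/[C@@H](OC(=O)C=C(C)C)[C@](C)(O)/C=C/[C@H](O)/C(CO)=C\C1`, is the second member of the set; in this assay compound 2 gives > 40000 nM, which is also a limit, (the limit of > 40000 nM in this assay, at which 1 of the 3 values shown sits). Going by the values given here, compound 3, `CC(C)=CCC[C@](C)(/C=C/[C@@H](OC(=O)C=C(C)C)[C@](C)(O)/C=C/C(=O)/C=C/N1CCN(C)CC1)CC=O`, is the only compound with a number: in this assay compound 3 gives 12400 nM. Among the compounds with values here, no pair of measured compounds differs in one place only, so no measured step is available to guide the next change.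

Compound 4, `CC(C)=CCC[C@]1(C)/C=C/[C@@H](OC(=O)C=C(C)C)[C@](C)(O)/C=C/C(=O)/C(C(=O)N(C(C)C)C(C)C)=C\C1`, differs from compound 1 by diisopropylamino in place of hydroxy on a carbonyl carbon, the change sitting on a carbonyl carbon whose other neighbours are a double-bonded ring carbon; cut one bond further out it reads carboxy to diisopropylcarbamoyl. With compound 1 sitting only at a limit, the direction of this step cannot be read from measured data, and no more than a moderate shift beyond the scatter is foreseen. Compound 4 is expected to give 8000 nM, with a range from 2000 nM to 40000 nM. That estimate corresponds to an expected step of an at least 1.2-fold lower number from compound 1 to compound 4 (0.09 log units; that floor lies within the scatter).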

Compound 4, half-maximal inhibitory concentration: 16000 nM
For compound 4 the middle estimate is 2.0-fold (0.30 log units) below the measured one; low and high end bracket the measured number.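

The step from compound 1 to compound 4 cannot be read, since compound 1 stands only at a limit of the assay: the limit of > 10000 nM in this assay, at which 1 of the 4 values shown sits.

The compounds shown leave open how far carboxy to diisopropylcarbamoyl moves the read-out in this assay, and what any other single change on the shared core does.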